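The source may hold more compounds than are shown below. What is called first, only, known or untested is meant among the compounds shown, and "the series" means these compounds.

Compound 2 `COc1cc(C(=O)/C=C/c2c(-c3ccc(F)cc3)nc3ncccn23)cc(OC)c1OC` was tested in a functional assay on U-251 cells (Homo sapiens) for inhibition, read by sulforhodamine B assay, with a stated time of 48 h (on this read-out lower numbers stand for stronger inhibition of growth and higher numbers for weaker inhibition of growth), and gave 1680 nM. Going by the values given here, only one other compound has been measured there: compound 1 `COc1cc(C(=O)/C=C/c2c(-c3cccs3)nc3ccccn23)cc(OC)c1OC` gave 1660 nM. Of these two numbers, that of compound 2 is the higher, but the gap to compound 1 is within the usual scatter, so the two compounds cannot be told apart by this measurement. Compound 3 `COc1ccc(-c2nc3ncccn3c2/C=C/C(=O)c2cc(OC)c(OC)c(OC)c2)cc1` has not yet been measured. It differs from compound 2 in one place: methoxy in place of fluoro on an aromatic carbon on the phenyl group attached to the shared core. Among the compounds with values here, no measured pair shows the effect of exactly this exchange, so the size of the step is uncertain. The growth inhibition of compound 3 is expected to be close to that of compound 2, with a step from a 1.1-fold lower number from compound 2 to compound 3 (0.05 log units; within the scatter) of no more than the scatter. For compound 3 the estimate in this assay is 1500 nM, within a range from 500 nM to 4500 nM.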

Compound 3, concentration for 50% growth inhibition: 1290 nM
Compound 3: middle estimate off by 1.2-fold (0.07 log units), on the high side, within the range that was stated.
By their numbers in this assay, from the lowest: compounds 3, 1 and 2 (each within the scatter of the next).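

Going by these compounds alone, the change from 4-fluorophenyl to 4-methoxyphenyl gives the first direct reading of a single exchange at this position: a 1.3-fold lower number from compound 2 to compound 3 (0.11 log units; within the scatter) in this assay. At this place, para to a large group, methoxy with its two heavy atoms and one hydrogen-bond acceptor can stand in for fluoro without a change that this measurement can distinguish from repeat-to-repeat variation. Nothing else measured here bears on why the two compounds behave alike.

From the compounds shown here alone, it remains open whether an amine, a carboxylic acid or a longer chain such as butoxy would also leave growth inhibition unchanged at this position. A single pair also cannot show whether the exchange of fluoro for methoxy would have an equally small effect on a different core.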